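A Methyl Step Repeated on a Different Chain Carbon

The source may hold more compounds than are shown below. What is called first, only, known or untested is meant among the compounds shown, and "the series" means these compounds.

Compound 1, `Cc1nn(C)c2c1C(c1ccccc1Cl)=NCCN2C`: 2.5 mg/kg
Compound 2, `CCn1nc(C)c2c1N(C)CCN=C2c1ccccc1Cl`: 5 mg/kg
Compound 3, `Cc1cccc(C2=NCCNc3c2c(C)nn3C)c1`: 2.5 mg/kg

In a functional assay on the whole organism for positive allosteric modulation, with Rattus norvegicus as the target (a lower number here means that less compound is needed, a higher number that more compound is needed for the effect), compound 1 and compound 3 give numbers level with each other, while compound 2 sits close by. Compound 2 differs from compound 1 by methyl in place of hydrogen on a saturated chain carbon bound to an aromatic nitrogen, and that step read a 2.0-fold higher number from compound 1 to compound 2 (0.30 log units; within the scatter). Compound 4 `CCc1nn(C)c2c1C(c1cccc(C)c1)=NCCN2` differs from compound 3 by methyl in place of hydrogen on a saturated chain carbon bound to an aromatic carbon. This is the same kind of change, but the place differs: in the first pair the carbon is bound to an aromatic nitrogen, in the second to an aromatic carbon. How the cores of compound 1 and compound 3 differ is not broken down here. Because a 2.0-fold higher number from compound 1 to compound 2 (0.30 log units; within the scatter) stayed within the scatter, the step of a 1.4-fold higher number from compound 3 to compound 4 (0.15 log units; within the scatter) is expected to be similarly small. Compound 4 is therefore estimated at 3.5 mg/kg, with a range from 1.5 mg/kg to 8 mg/kg.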

Compound 4, minimum effective dose: 5 mg/kg
Compound 4: middle estimate off by 1.4-fold (0.15 log units), on the low side; measured number inside the range.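

In this assay, the new step reads a 2.0-fold higher number from compound 3 to compound 4 (0.30 log units; within the scatter). Set beside the earlier step, the methyl change gives matching results on the two cores: the same change on two cores in this assay, a 2.0-fold higher number (0.30 log units; within the scatter) from compound 1 to compound 2 and a 2.0-fold higher number (0.30 log units; within the scatter) from compound 3 to compound 4, 1.0-fold (0.00 log units) apart, within the scatter of two such steps. Both steps lie within the scatter, which means the pair shows agreement only for a small step, and it does not show that a larger effect would carry over, that the same result would hold on a third core, or how much the different place of the methyl matters, as place and core differ together here.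

The compounds shown leave open what a longer chain, such as propyl, would do at either place. They also leave open how an amine or a carboxylic acid on that chain would read in this assay.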